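This account rests on a few compounds, and the source may have more. Where it says the series, first, only, none or still open, it means among the compounds named here.

The measured compounds:

Compound 1, `C/C=C1/[C@H](O[C@@H]2O[C@H](CO)[C@@H](O)[C@H](O)[C@H]2O)OC=C(C(=O)OC)[C@H]1CC(=O)OCCc1ccc2c(c1)OCCO2`; in this assay compound 1 gives > 20000 nM, a limit of the assay rather than a number.
Compound 2, `C/C=C1/[C@H](O[C@@H]2O[C@H](COC(C)=O)[C@@H](OC(C)=O)[C@H](OC(C)=O)[C@H]2OC(C)=O)OC=C(C(=O)OC)[C@H]1CC(=O)OCCC1CCCCC1`; compound 2 gives > 15000 nM, again a limit.
Compound 3, `C/C=C1/[C@H](O[C@@H]2O[C@H](COC(C)=O)[C@@H](OC(C)=O)[C@H](OC(C)=O)[C@H]2OC(C)=O)OC=C(C(=O)OC)[C@H]1CC(=O)OCCC(C)C`; compound 3 gives > 15000 nM, also a limit.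

Among the measured compounds shown here, all three values in a functional assay on SK-BR-3 cells (Homo sapiens) for antiproliferative activity, read by MTT assay, with a stated time of 72 h (on this read-out higher numbers stand for weaker inhibition and lower numbers for stronger inhibition), are therefore limits, and the only single-point step among them, a step that the two limits leave unreadable from compound 2 to compound 3, cannot be read in size or direction. Compound 1 stands at the limit of > 20000 nM in this assay, at which 1 of the 3 values shown sits, while compound 2 and compound 3 stand at the limit of > 15000 nM in this assay, at which 2 of the 3 values shown sit; nothing in these numbers separates compound 1 from the other two.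

Compound 4, `C/C=C1/[C@H](O[C@@H]2O[C@H](CO)[C@@H](O)[C@H](O)[C@H]2O)OC=C(C(=O)OC)[C@H]1CC(=O)OCCc1ccc(O)cc1`, differs from compound 1 in one place: 4-hydroxyphenyl in place of 2,3-dihydro-1,4-benzodioxin-6-yl on a saturated chain carbon, two bonds along the chain from an oxygen next to a carbonyl group. For the measured compounds named here, no measured step covers this change, and the one step that exists is unreadable, so no direction beyond the scatter can be read from the data. Compound 1 sits at a limit, and compound 4 is expected to stay near that limit too, with the step that the limit leaves unreadable from compound 1 to compound 4 being the estimated change. The estimated value for compound 4 is 25000 nM, within a range of 6000 nM to 100000 nM.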

Compound 4, half-maximal inhibitory concentration: > 20000 nM
Compound 4: no number, only a limit; the forecaster's own chance of this, stated with the estimate: 70%; the middle value lies beyond the limit too.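

In this assay compound 4 gives > 20000 nM, a limit and not a number. Compound 1 also stands at a limit, and no step can be read between compound 1 and compound 4. The compounds shown leave open whether any change on the shared core gives a measurable value in this assay.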